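A second chloro on the aryl group of compound 2

This account rests on a few compounds, and the source may have more. Where it says the series, first, only, none or still open, it means among the compounds named here.

Measured compounds:
Compound 1, `CC(C)(C)c1nnc2nnc(N3CCCC3)nn12`: in a functional assay on HL-60 cells (Homo sapiens) for cytotoxicity, read by MTT assay, with a stated time of 72 h (a higher number here means a weaker inhibitor, a lower number a stronger inhibitor), compound 1 gives > 100000 nM, which is a limit of the assay and not a number.
Compound 2, `Clc1ccccc1-c1nnc2nnc(N3CCCC3)nn12`: in this assay compound 2 gives 2660 nM.

Compound 2 therefore stands with the only number shown in this assay; the one other value is a limit. For the measured compounds named here, the single measured step, an at least 37-fold lower number from compound 1 to compound 2 (1.57 log units; beyond the scatter), exchanges a whole group on the shared core, and its size rests on (the limit of > 100000 nM in this assay, at which 1 of the 2 values shown sits), so only its lower bound is known.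

The unmeasured compound 3, `Clc1ccc(-c2nnc3nnc(N4CCCC4)nn23)c(Cl)c1`, differs from compound 2 by chloro in place of hydrogen on an aromatic carbon. Going by the values given here, no measured step concerns an exchange of hydrogen for chloro on the aryl ring; the step from compound 1 to compound 2 replaced the entire substituent and does not carry over to this smaller change. The evidence offers no direction for a second chloro, so the expectation is a step in this assay that does not leave the scatter. The expected step of a 1.2-fold lower number from compound 2 to compound 3 (0.08 log units; within the scatter) is accordingly small. Compound 3 is estimated at 2200 nM, within a range from 700 nM to 7000 nM.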

Compound 3, half-maximal inhibitory concentration: 8650 nM
The estimate for compound 3 lay 3.9-fold (0.59 log units) below the measured number; measured number outside the range, above it.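

In this assay, chloro in place of hydrogen on the aromatic carbon that is meta to a chloro group and para to a large group gives a 3.3-fold higher number from compound 2 to compound 3 (0.51 log units; beyond the scatter), so this position on the aryl ring is not indifferent to a small change. The earlier comparison exchanged a whole substituent on the shared core, whereas this one adds a single heavy atom to an aryl group that is kept, and the number moves beyond the scatter. It also moves upward, so the gain seen on going from the tert-butyl group to the 2-chlorophenyl group does not extend to a second chloro at this position, though nothing shown here accounts for this step.

The compounds shown leave open whether the rise belongs to chloro itself or would also follow from a fluoro, methoxy or amino group at this position. They also leave open how much the first chloro contributes, which a plain phenyl group on the same core would begin to answer, and whether the second chloro would have the same effect without it.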